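A few compounds are considered here, and "the series" means these few. Any claim that something is new, unique, unknown or untested is made for them only; others in the source may bear on it.

Measured compounds:
- compound 1, `Cc1nc(N(C)c2ccc([Se]C#N)c(Cl)c2)c2ccccc2n1`, which in a functional assay on LoVo cells (Homo sapiens) for inhibition, read by MTT assay, with a stated time of 48 h (on this read-out lower numbers stand for stronger inhibition and higher numbers for weaker inhibition), gives 12 nM
- compound 2, `COc1ccc(N(C)c2nc(C)nc3ccccc23)cc1C(=O)NCC[Se]C#N`, which gives 561 nM
- compound 3, `COc1ccc(N(C)c2nc(C)nc3ccccc23)cc1C(=O)OCCC[Se]C#N`, which gives 854 nM

Compound 1 gives the lowest number of the three, and the gaps to compound 2 and to compound 3 both lie well beyond the scatter, so it is the most potent of the measured set. Among the compounds with values here, compound 2 and compound 3 share a core variant that differs from compound 1 in several places at once; the only single-point step among them is a 1.5-fold higher number from compound 2 to compound 3 (0.18 log units; within the scatter), a change on a carbonyl carbon of the side chain that is not present in compound 1.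

Compound 4, `Cc1nc(N(C)c2ccc([Se]C#N)c(F)c2)c2ccccc2n1`, differs from compound 1 in one place: fluoro in place of chloro on an aromatic carbon. Within the data shown here, no measured pair in the set exchanges one halogen for another on the aromatic ring, so no step bears directly on this change; the step from compound 2 to compound 3 concerns a different position and a different substituent class. With nothing to indicate otherwise, compound 4 is expected to stay close to compound 1, a step of a 1.5-fold higher number from compound 1 to compound 4 (0.18 log units; within the scatter), not beyond the scatter. The estimate for compound 4 is 18 nM, with a range from 6 nM to 55 nM.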

Compound 4, half-maximal inhibitory concentration: 13 nM
Compound 4: the middle estimate sits 1.4-fold (0.14 log units) above what was measured, within the range that was stated.
By their numbers in this assay, from the lowest: compounds 1 and 4 (each within the scatter of the next); then compounds 2 and 3 (each within the scatter of the next).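

In this assay, fluoro in place of chloro on an aromatic carbon gives a 1.1-fold higher number from compound 1 to compound 4 (0.03 log units; within the scatter). Within the data shown here, this is the first halogen exchange on this ring, and it shows that the two halogens cannot be told apart here: at this position, the read-out does not separate a single fluorine from a single chlorine. No supporting measurement is available to account for this outcome.

Still open, as far as these compounds go, is whether the tolerance seen here extends beyond these two halogens, since a bare hydrogen, a bromo, a methoxy, a trifluoromethyl or an amine on the same aromatic carbon would test how much change this position accepts before the number moves beyond the scatter. Also open, from the compounds shown here alone, is whether the same exchange of chloro for fluoro would give a step of similar size on a compound carrying the longer carbonyl side chain of compound 2 or compound 3.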